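The source may report more compounds than this note shows. Statements on the series, on what has been measured and on what is new or still open speak of the compounds shown alone.

Compounds measured so far:
- compound 1, `Cc1ccccc1Cc1ccc(N2C[C@@H](C(F)(F)F)C[C@H]2CC(=O)O)cc1`, 67 nM
- compound 2, `COc1ccc(Oc2ccc(N3C[C@@H](C(F)(F)F)C[C@H]3CC(=O)O)cc2)c(C)c1`, 55 nM
- compound 3, `Cc1c(Cl)cccc1Oc1ccc(N2C[C@@H](C(F)(F)F)C[C@H]2CC(=O)O)cc1`, 82 nM

All three numbers come from a functional assay on cells for agonist activity at Free fatty acid receptor 1 (Homo sapiens), read by FLIPR and calcium flux, with a stated time of 100 s; a lower number here means that less compound is needed, a higher number that more compound is needed for the effect. Compound 3 is the point of departure here. The two measured steps that lead to it are a 1.2-fold higher number from compound 1 to compound 3 (0.09 log units; within the scatter) and a 1.5-fold higher number from compound 2 to compound 3 (0.17 log units; within the scatter); both lie within the scatter, so the three compounds cannot be told apart on these numbers, and compound 3 stands together with compound 1 and compound 2 rather than apart from them.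

The step to the unmeasured compound 4, `Cc1cccc(C)c1Oc1ccc(N2C[C@@H](C(F)(F)F)C[C@H]2CC(=O)O)cc1`, is 2,6-dimethylphenyl in place of 3-chloro-2-methylphenyl on an oxygen on an aromatic ring. Of the measured steps, the one that bears on it is the step from compound 2 to compound 3, which also swapped the aryl group on the oxygen on an aromatic ring and gave a 1.5-fold higher number from compound 2 to compound 3 (0.17 log units; within the scatter), a change within the scatter. The step from compound 1 to compound 3, a 1.2-fold higher number from compound 1 to compound 3 (0.09 log units; within the scatter), alters a different part and is also within the scatter. On this basis, no step beyond the scatter is expected in this assay: the estimate for the step from compound 3 to compound 4 is a 1.0-fold lower number from compound 3 to compound 4 (0.01 log units; within the scatter).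

Compound 4 is therefore expected to give about 80 nM, with a range from 35 nM to 180 nM.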

Compound 4, half-maximal effective concentration: 82 nM
Compound 4: the middle estimate sits 1.0-fold (0.01 log units) below what was measured; low and high end bracket the measured number.
By their numbers in this assay, from the lowest: compounds 2, 1, 3 and 4 (each within the scatter of the next).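

Swapping 3-chloro-2-methylphenyl for 2,6-dimethylphenyl on the oxygen on an aromatic ring gives, in this assay, no change at the digits printed from compound 3 to compound 4 (within the scatter), so the chlorine of compound 3 can give way to carbon alone in this aryl group without a step that can be read. The comparison with the other two compounds agrees, with a 1.5-fold higher number from compound 2 to compound 4 (0.17 log units; within the scatter) and a 1.2-fold higher number from compound 1 to compound 4 (0.09 log units; within the scatter), and all four compounds therefore stand together, whether this aryl group carries chlorine, methoxy or only methyl, and whether it is joined through oxygen or, as 2-methylbenzyl, through carbon. Nothing available here offers a reason for this flatness.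

The aryl groups shown carry only methyl, methoxy and chlorine, so it stays open whether an amine, a nitrile or a longer chain on this ring would move the number beyond the scatter. From the compounds shown here alone, the carboxylic acid and the trifluoromethyl group are common to all four compounds, so what an amide in place of the acid, or hydrogen in place of the trifluoromethyl group, would do in this assay also remains open.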